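Pyrrolidin-1-yl for diethylamino, repeated on a second core

The source may hold more compounds than are shown below. What is called first, only, known or untested is meant among the compounds shown, and "the series" means these compounds.

compound 1 `CCN(CC)C/C=C/C(=O)Nc1cc2c(N3CCCc4ccccc43)ncnc2cc1OC`: 6890 nM
compound 2 `COc1cc2ncnc(N3CCCc4ccccc43)c2cc1NC(=O)/C=C/CN1CCCC1`: 1740 nM
compound 3 `CCN(CC)C/C=C/C(=O)Nc1cc2c(N3CCCc4ccccc43)ncnc2cc1O[C@@H]1CCOC1`: 4270 nM

All three numbers come from a functional assay on PC-3 cells (Homo sapiens) for antiproliferative activity, read by MTT assay, with a stated time of 72 h; a lower number here means a stronger inhibitor, a higher number a weaker inhibitor. Compound 1 and compound 2 differ only in pyrrolidin-1-yl in place of diethylamino on a saturated chain carbon bound to a double-bonded chain carbon, and that change gave a 4.0-fold lower number from compound 1 to compound 2 (0.60 log units; beyond the scatter). Compound 3 carries a different core, differing from compound 1 by oxolan-3-yl in place of methyl on an oxygen on an aromatic ring; that change gave a 1.6-fold lower number from compound 1 to compound 3 (0.21 log units; within the scatter), so compound 1 and compound 3 are treated as equivalent here.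

Compound 4 `O=C(/C=C/CN1CCCC1)Nc1cc2c(N3CCCc4ccccc43)ncnc2cc1O[C@@H]1CCOC1` is not yet measured. Among the measured compounds shown here, it differs from compound 3 by pyrrolidin-1-yl in place of diethylamino on a saturated chain carbon bound to a double-bonded chain carbon, which is the same change as the one between compound 1 and compound 2, at the same place. For the measured compounds named here, only one earlier instance of the change is available, so the expectation rests on that pair alone and on compound 3 as the starting point. For compound 4 the step of a 3.6-fold lower number from compound 3 to compound 4 (0.55 log units; beyond the scatter) is expected, set beside the measured step from compound 1 to compound 2 because that step read a 4.0-fold lower number from compound 1 to compound 2 (0.60 log units; beyond the scatter). Compound 4 is therefore estimated at 1200 nM, with a range from 500 nM to 3000 nM in this assay.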

Compound 4, half-maximal inhibitory concentration: 5780 nM
For compound 4 the middle estimate is 4.8-fold (0.68 log units) below the measured one, outside the stated range (above it).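

In this assay, pyrrolidin-1-yl in place of diethylamino gave a 1.4-fold higher number from compound 3 to compound 4 (0.13 log units; within the scatter), so the gain seen with the methyl group on the oxygen did not carry over to the core of compound 3: the same change on two cores in this assay, a 4.0-fold lower number (0.60 log units; beyond the scatter) from compound 1 to compound 2 and a 1.4-fold higher number (0.13 log units; within the scatter) from compound 3 to compound 4, 5.4-fold (0.73 log units) apart, beyond the scatter of two such steps. Read the other way, oxolan-3-yl in place of methyl on an oxygen on an aromatic ring gave a 3.3-fold higher number from compound 2 to compound 4 (0.52 log units; beyond the scatter), so the effect of that change also depends on which amine the compound carries: the same change on two cores in this assay, a 1.6-fold lower number (0.21 log units; within the scatter) from compound 1 to compound 3 and a 3.3-fold higher number (0.52 log units; beyond the scatter) from compound 2 to compound 4, 5.4-fold (0.73 log units) apart, beyond the scatter of two such steps. The four compounds show that the two changes do not add up in this series, but as a single set of four from one assay they do not show why, nor whether this holds for other changes at either place.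

On these data alone, it remains open whether another amine on the same chain carbon, such as dimethylamino or piperidin-1-yl, would track compound 2 or compound 4 across the two oxygen substituents. A further group on the oxygen, such as ethyl or a longer chain ending in morpholin-4-yl, would show whether the pyrrolidin-1-yl gain is confined to the methyl compounds.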